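Fluoro for trifluoromethyl on the phenylpiperidine arm

The source may hold more compounds than are shown below. What is called first, only, known or untested is meant among the compounds shown, and "the series" means these compounds.

Measured so far:
compound 1 `Cn1c(CN2CCC(c3ccccc3)CC2)nc2ccccc21` — 6310 nM
compound 2 `Cn1c(CN2CCC(c3ccc(Cl)cc3)CC2)nc2ccccc21` — 5010 nM
compound 3 `Cn1c(CN2CCC(c3ccccc3C(F)(F)F)CC2)nc2ccccc21` — 6310 nM

In a functional assay on CHO cells for agonist activity at metabotropic glutamate receptor 2 (Homo sapiens), read by FLIPR (on this read-out higher numbers stand for an effect only at larger amounts of compound and lower numbers for an effect already at smaller amounts), compound 3 gives 6310 nM, level with compound 1 at the digits printed; the two steps taken so far are no change at the digits printed from compound 1 to compound 3 (within the scatter) and a 1.3-fold lower number from compound 1 to compound 2 (0.10 log units; within the scatter). Compound 4 `Cn1c(CN2CCC(c3ccccc3F)CC2)nc2ccccc21` differs from compound 3 in one place: fluoro in place of trifluoromethyl on an aromatic carbon. Both earlier substitutions on that aromatic ring left the read-out unchanged within scatter, so for compound 4 the expected step is also no change beyond scatter, a 1.1-fold lower number from compound 3 to compound 4 (0.02 log units; within the scatter). Compound 4 is therefore estimated at 6000 nM, with a range from 2500 nM to 15000 nM.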

Compound 4, half-maximal effective concentration: 3980 nM
Compound 4: middle estimate off by 1.5-fold (0.18 log units), on the high side; low and high end bracket the measured number.
By their numbers in this assay, from the lowest: compounds 4, 2, 1 and 3 (each within the scatter of the next).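

In this assay the step to fluoro on this aromatic carbon is a 1.6-fold lower number from compound 1 to compound 4 (0.20 log units; within the scatter) from hydrogen and a 1.6-fold lower number from compound 3 to compound 4 (0.20 log units; within the scatter) from trifluoromethyl, so exchanging 4 heavy atoms for 1 here moves nothing beyond the scatter. Placing 2-fluorophenyl where 4-chlorophenyl stood gives a 1.3-fold lower number from compound 2 to compound 4 (0.10 log units; within the scatter) as well, so none of the three new steps separates its compounds. No measured evidence bears on this result.

The compounds shown carry only hydrogen or halogen-bearing groups on this ring. From the compounds shown here alone, whether an amine, a carboxylic acid or a methoxy group there would shift the read-out beyond the scatter stays open.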